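A few compounds are considered here, and "the series" means these few. Any claim that something is new, unique, unknown or untested is made for them only; others in the source may bear on it.

Measured compounds:
compound 1 `O=C(Nc1cccc(C(=O)O)c1)Nc1ccc(F)c(C(F)(F)F)c1` — < 7 uL/min (a limit of the assay)
compound 2 `N#Cc1ccc(NC(=O)Nc2ccc(F)c(C(F)(F)F)c2)cc1` — < 7 uL/min (a limit of the assay)
compound 3 `Cc1cc(NC(=O)Nc2ccc(F)c(C(F)(F)F)c2)on1` — 73 uL/min

In an ADME assay on microsomes from liver (Homo sapiens) for metabolic stability, using NADPH, with a stated time of 60 min (on this read-out higher numbers stand for fast clearance and lower numbers for slow clearance), compound 2 gives < 7 uL/min, which is a limit of the assay and not a number. This is the limit of < 7 uL/min in this assay, at which 2 of the 3 values shown sit. Compound 1 sits at the same kind of limit with < 7 uL/min. Compound 3 gives a numeric value of 73 uL/min.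

Compound 4 `CC(=O)c1ccc(NC(=O)Nc2ccc(F)c(C(F)(F)F)c2)cc1` differs from compound 2 by acetyl in place of cyano on an aromatic carbon. For the measured compounds named here, no measured step joins these two structures. In this assay the expected step is an at least 1.7-fold higher number from compound 2 to compound 4 (0.23 log units; that floor lies within the scatter), a modest rise, close to the scatter. Compound 4 is estimated at 12 uL/min, with a range from 5 uL/min to 30 uL/min.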

Compound 4, intrinsic clearance in a liver preparation (reported as CLH), per the amount of preparation that the assay uses in the Homo sapiens assay: 16 uL/min
Compound 4: middle estimate off by 1.3-fold (0.12 log units), on the low side; the range from low to high includes it.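

Acetyl in place of cyano on an aromatic carbon gives the first step that can be read at this position in the Homo sapiens assay, with an at least 2.2-fold higher number from compound 2 to compound 4 (0.35 log units; beyond the scatter). Its size is only a floor, because compound 2 stands at a limit of the assay: the limit of < 7 uL/min in the Homo sapiens assay, at which 2 of the 4 values shown sit. In a physicochemical assay for lipophilicity, read by HPLC, measured as octanol-water partition, at pH 7.2 (on this read-out lower numbers stand for lower lipophilicity and higher numbers for higher lipophilicity), compound 2 gives 3.8 and compound 4 gives 3.6, values within the usual scatter of each other, so this read-out does not separate the two compounds.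

On these data alone, how far the true step exceeds its floor remains open. So does whether a propanoyl group or a primary amide at this position would read nearer compound 2 or compound 4.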